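Swapping the biaryl arm for tert-butyl in compound 4

The source may hold more compounds than are shown below. What is called first, only, known or untested is meant among the compounds shown, and "the series" means these compounds.

Measured compounds:
Compound 1 `COC(=O)/C=C/c1cccc(N(Cc2ccc(-c3ccc(OC)cc3)cc2)C(=O)C2CCCCC2)c1` gives 89 nM in an assay on isolated protein with Bile acid receptor (Homo sapiens) as the target; on this read-out higher numbers stand for an effect only at larger amounts of compound and lower numbers for an effect already at smaller amounts.
Compound 2 `COC(=O)/C=C/c1cccc(N(Cc2ccc(-c3ccc(OC)cc3)cc2)C(=O)C(C)C)c1` gives 97 nM in this assay.
Compound 3 `COC(=O)/C=C/c1cccc(N(Cc2ccc(-c3cccc(OC(F)(F)F)c3)cc2)C(=O)C(C)C)c1` gives 247 nM in this assay.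

Compound 1 has the lowest number of the three, but its gap to compound 2 is small: a 1.1-fold higher number from compound 1 to compound 2 (0.04 log units; within the scatter). Only the gap to compound 3 is clear, and that gap comes from a change at the aromatic arm rather than at the carbonyl side.

Compound 4 `COC(=O)/C=C/c1cccc(N(Cc2ccc(C(C)(C)C)cc2)C(=O)C2CCCCC2)c1` differs from compound 1 at that same arm: tert-butyl in place of 4-methoxyphenyl on an aromatic carbon. Within the data shown here, no measured step replaces this aromatic arm with a group that has no ring, so the nearest guide is the one change made there, which weakened binding: a 2.5-fold higher number from compound 2 to compound 3 (0.41 log units; beyond the scatter). Since even a different aromatic ring at this place cost a modest amount, removing the ring in favour of tert-butyl is expected to cost somewhat more, and compound 4 is estimated at 350 nM (range 120 nM to 1200 nM). Among the measured compounds shown here, this expected step, a 3.9-fold higher number from compound 1 to compound 4 (0.59 log units; beyond the scatter), is uncertain because a 2.5-fold higher number from compound 2 to compound 3 (0.41 log units; beyond the scatter) is the only related evidence.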

Compound 4, half-maximal effective concentration: > 1000 nM
Compound 4: only a limit was reported; the forecaster's own chance of this, stated with the estimate: 5%; middle value at least 2.8-fold (0.45 log units) away from the limit.
By their numbers in this assay, from the lowest: compounds 1 and 2 (each within the scatter of the next); then compound 3. At a limit, above all of these: compound 4.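

In this assay, compound 4 gives > 1000 nM, which is a limit of the assay and not a number. Putting tert-butyl in place of 4-methoxyphenyl gives an at least 11-fold higher number from compound 1 to compound 4 (1.05 log units; beyond the scatter), so this position allows a far larger loss than the swap between two aromatic rings showed, a 2.5-fold higher number from compound 2 to compound 3 (0.41 log units; beyond the scatter), while the change on the carbonyl side stayed small, a 1.1-fold higher number from compound 1 to compound 2 (0.04 log units; within the scatter). The true size of the new step stays unknown, and the printed figure is only its lower bound, because the reading stops at a limit: the limit of > 1000 nM in this assay, at which 1 of the 4 values shown sits.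

The compounds shown cannot say whether the loss follows from removing the ring or from shortening the arm, since both happen together in compound 4. A plain phenyl or a piperidine ring on this aromatic carbon would help separate the two.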